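The source may hold more compounds than are shown below. What is called first, only, known or untested is meant among the compounds shown, and "the series" means these compounds.

Measured compounds:
- compound 1 `Cc1cc(C)cc(S(=O)(=O)c2c(C(=O)NCN3CCCC3)[nH]c3ccc(Br)cc23)c1`: 9600 nM
- compound 2 `Cc1cc(C)cc(S(=O)(=O)c2c(C(=O)NCCOc3ccccc3)[nH]c3ccc(Cl)c(F)c23)c1`: 11000 nM
- compound 3 `Cc1cc(C)cc(S(=O)(=O)c2c(C(=O)NCN3CCCC3)[nH]c3ccc(Cl)c(F)c23)c1`: 9300 nM

In an ADME assay on CCRF-CEM cells (Homo sapiens) for cytotoxicity, read by cell counting (a lower number here means that less compound is tolerated, a higher number that more compound is tolerated), compound 1 gives 9600 nM, the second highest of the three numbers; its nearest neighbour is compound 3 and its furthest is compound 2, and both gaps lie within the scatter, so the three measured compounds cannot be told apart in this assay.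

Compound 4 `Cc1cc(C)cc(S(=O)(=O)c2c(C(=O)NCc3ccccc3)[nH]c3ccc(Br)cc23)c1` is not yet measured. Against compound 1 the change is phenyl in place of pyrrolidin-1-yl on a saturated chain carbon bound to an amide-type nitrogen. For the measured compounds named here, the one measured step that concerns the same place is a 1.2-fold lower number from compound 2 to compound 3 (0.07 log units; within the scatter), where a group carrying an aromatic ring was exchanged for pyrrolidin-1-yl without any shift beyond the scatter. The same place now carries an exchange in the opposite sense, so no step beyond the scatter is expected in this assay; the step is expected to be a 1.0-fold higher number from compound 1 to compound 4 (0.02 log units; within the scatter). Compound 4 is therefore expected to give 10000 nM, with a range of 5000 nM to 20000 nM.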

Compound 4, half-maximal cytotoxic concentration: 172000 nM
Beside the measured number, compound 4's estimate is 17-fold (1.24 log units) below it, outside the stated range (above it).
By their numbers in this assay, from the lowest: compounds 3, 1 and 2 (each within the scatter of the next); then compound 4.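

In this assay this place proves able to carry a large step: phenyl in place of pyrrolidin-1-yl gives an 18-fold higher number from compound 1 to compound 4 (1.25 log units; beyond the scatter) on the core of compound 1, whereas phenoxymethyl exchanged for pyrrolidin-1-yl gave a 1.2-fold lower number from compound 2 to compound 3 (0.07 log units; within the scatter) and stayed within the scatter. An aromatic ring in the group at this place does not by itself go with a large step, as compound 2 carries one and stands within the scatter of compound 3, though the two exchanges sit on cores with different halogens. Nothing at hand gives a measured reason for the size of this step.

Open, going by these compounds, is whether phenyl gives a step of this size on the core of compound 3. Also open, on these data alone, is whether cyclohexyl or piperidin-1-yl at the same place reads like phenyl or like pyrrolidin-1-yl.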